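Amino replaces methoxy on the pendant ring of compound 2

The source may report more compounds than this note shows. Statements on the series, on what has been measured and on what is new or still open speak of the compounds shown alone.

Compound 2 `COc1ccc(/C=C2\Cc3c(cc(OC)c(OC)c3OC)C2=O)cc1OC` gives 7470 nM in a functional assay on PC-3 cells (Homo sapiens) for antiproliferative activity, read by MTT assay, with a stated time of 48 h (a lower number here means a stronger inhibitor of growth, a higher number a weaker inhibitor of growth), the higher of the two numbers available, while compound 1 `COc1ccc(/C=C2\Cc3c(cc(OC)c(OC)c3OC)C2=O)cc1[N+](=O)[O-]` gives 1560 nM. Going by the values given here, the single measured step, a 4.8-fold higher number from compound 1 to compound 2 (0.68 log units; beyond the scatter), concerns the very carbon now altered again. Compound 3 `COc1ccc(/C=C2\Cc3c(cc(OC)c(OC)c3OC)C2=O)cc1N` differs from compound 2 by amino in place of methoxy on an aromatic carbon. Among the compounds with values here, that earlier step shows this position can shift the number modestly, but no measured pair contains an amino group, so the direction remains open. For compound 3 the expected value in this assay is 3000 nM, within 800 nM to 12000 nM, an estimated step of a 2.5-fold lower number from compound 2 to compound 3 (0.40 log units; beyond the scatter).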

Compound 3, concentration for 50% growth inhibition: 456 nM
For compound 3 the middle estimate is 6.6-fold (0.82 log units) above the measured one, outside the stated range (below it).
By their numbers in this assay, from the lowest: compound 3; then compound 1; then compound 2.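

In this assay the change from methoxy to amino on this aromatic carbon brings a 16-fold lower number from compound 2 to compound 3 (1.21 log units; beyond the scatter) and the change from nitro to amino brings a 3.4-fold lower number from compound 1 to compound 3 (0.53 log units; beyond the scatter) on the same shared core. This position can therefore move the number much further than the earlier nitro and methoxy pair showed, and amino gives the lowest number of the three groups, with both of its steps beyond the scatter. Nothing at hand explains this difference between the groups. Still open, on these data alone, is whether a methylamino, dimethylamino or acetamido group on this carbon would keep the low number of compound 3.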